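The source may hold more compounds than are shown below. What is called first, only, known or untested is meant among the compounds shown, and "the series" means these compounds.

The three measured compounds, with their numbers in an assay on RPMI-8226 cells for antagonist activity at P2X purinoceptor 7 (Homo sapiens), read by calcium flux; a higher number here means a weaker inhibitor, a lower number a stronger inhibitor:

Compound 1 `O=c1[nH]c2ccccc2n1CCCCCN1CCN(C(c2ccccc2)c2ccccc2)CC1` gives 560 nM.
Compound 2 `Cc1nc2ccccc2n1CCCCN1CCN(C(c2ccccc2)c2ccccc2)CC1` gives 850 nM.
Compound 3 `Cc1ccc2ccn(CCCCN3CCN(C(c4ccccc4)c4ccccc4)CC3)c2c1` gives 6500 nM.

Compound 3 stands highest of the three. The step of a 12-fold higher number from compound 1 to compound 3 (1.06 log units; beyond the scatter) and the step of a 7.6-fold higher number from compound 2 to compound 3 (0.88 log units; beyond the scatter) both lie beyond the scatter, so compound 3 is the weakest inhibitor among the measured compounds. Compound 1 and compound 2 are separated by a 1.5-fold higher number from compound 1 to compound 2 (0.18 log units; within the scatter), which stays within the scatter.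

Compound 4 `N#Cc1cn(CCCCN2CCN(C(c3ccccc3)c3ccccc3)CC2)c2ccccc12` differs from compound 3 in one place: a group of 11 heavy atoms (9 carbon, 2 nitrogen; one five-membered aromatic ring with 1 hetero atom, one six-membered aromatic ring of carbon only) in place of a group of 10 heavy atoms (9 carbon, 1 nitrogen; one five-membered aromatic ring with 1 hetero atom, one six-membered aromatic ring of carbon only), on a saturated chain carbon, four bonds along the chain from an amine nitrogen in a ring. Within the data shown here, no measured step makes this same change. The two steps that reach compound 3 exchange the whole two-ring group, and in both the entering group with one hetero atom in the five-membered ring brought a higher number. The change from compound 3 to compound 4 keeps that ring and adds a nitrile, so the measured steps bear on it only loosely. A modest move back toward lower numbers is expected, a 4.3-fold lower number from compound 3 to compound 4 (0.64 log units; beyond the scatter), with wide uncertainty. Compound 4 is therefore estimated at 1500 nM, within 400 nM to 5000 nM.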

Compound 4, half-maximal inhibitory concentration: 1500 nM
Compound 4: the middle estimate sits on the measured number at the digits printed, and the stated range covers the measured number.
By their numbers in this assay, from the lowest: compounds 1, 2 and 4 (each within the scatter of the next, the first and the last beyond it); then compound 3.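

In this assay, a two-ring group with one hetero atom in the five-membered ring does not by itself bring the high number of compound 3: adding the nitrile group gives a clear shift (a 4.3-fold lower number from compound 3 to compound 4 (0.64 log units; beyond the scatter)), and the gap to the group with two hetero atoms in that ring closes to within the scatter (a 1.8-fold higher number from compound 2 to compound 4 (0.25 log units; within the scatter)). The group in compound 1, which carries the carbonyl, still stands apart beyond the scatter (a 2.7-fold higher number from compound 1 to compound 4 (0.43 log units; beyond the scatter)). Nothing shown here explains these shifts.

The compounds shown leave open whether the nitrile itself matters or whether a carboxylic acid or an amine on the same two-ring group would give a similar number. They also leave open how any of these groups would behave on a longer chain.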